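Ortho-to-meta chloro shift in a bicyclic urea series

The compounds below may be only part of what the source reports. "The series", "measured", "known", "first", "only" and "open" are said of these compounds alone.

Compound 1 `COc1ccc(NC(=O)NC2CC(C)(C)Oc3ccc(Cl)cc32)cc1`: in a functional assay (aorta) with Rattus norvegicus as the target (on this read-out higher numbers stand for an effect only at larger amounts of compound and lower numbers for an effect already at smaller amounts), compound 1 gives > 30000 nM, a limit of the assay.
Compound 2 `Cc1ccccc1NC(=O)NC1CC(C)(C)Oc2ccc(Cl)cc21`: in this assay compound 2 gives > 10000 nM, a limit of the assay.
Compound 3 `CC1(C)CC(NC(=O)Nc2ccccc2Cl)c2cc(Cl)ccc2O1`: in this assay compound 3 gives > 300000 nM, a limit of the assay.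

All three measured compounds share one core and differ only in the aryl group on the urea nitrogen. None of the three returned a number; each sits at a limit, and compound 3 sits at the limit of > 300000 nM in this assay, at which 1 of the 3 values shown sits. The steps among them are therefore unreadable: a step that the two limits leave unreadable from compound 1 to compound 2, a step that the two limits leave unreadable from compound 1 to compound 3 and a step that the two limits leave unreadable from compound 2 to compound 3.

Compound 4 `CC1(C)CC(NC(=O)Nc2cccc(Cl)c2)c2cc(Cl)ccc2O1` differs from compound 3 in one place: 3-chlorophenyl in place of 2-chlorophenyl on an amide-type nitrogen. The two steps that touch compound 3, namely a step that the two limits leave unreadable from compound 1 to compound 3 and a step that the two limits leave unreadable from compound 2 to compound 3, bear on this change but give no readable size, so no direction can be expected beyond the scatter. Compound 4 is therefore expected to remain weak in this assay, with an estimated step of an at least 3.0-fold lower number from compound 3 to compound 4 (0.47 log units; beyond the scatter). For compound 4 the estimate is 100000 nM, ranging from 10000 nM to 1000000 nM.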

Compound 4, half-maximal effective concentration: > 30000 nM
Compound 4: a limit, no number; the forecaster's own chance of this, stated with the estimate: 75%; the middle value does not contradict the limit.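

In this assay compound 4 gives > 30000 nM, a limit of the assay. The steps to compound 4 from compound 1, compound 2 and compound 3 cannot be read. The compounds shown leave open whether any of these aryl groups on the urea nitrogen gives a measurable effect.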